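Ester variation on the shared core: cytotoxicity notes

The source may hold more compounds than are shown below. What is called first, only, known or untested is meant among the compounds shown, and "the series" means these compounds.

Compound 3 `O=C(CN1C(=O)c2ccccc2C1=O)OCCc1c(-c2ccccc2Cl)c2cc(Cl)ccc2[nH]c1=O` gives 960000 nM in an ADME assay on HepG2 2.2.15 cells (Homo sapiens) for cytotoxicity (on this read-out lower numbers stand for higher toxicity in this test and higher numbers for lower toxicity in this test), the second highest of the three numbers: compound 2 `O=C(OCCc1c(-c2ccccc2Cl)c2cc(Cl)ccc2[nH]c1=O)c1ccc([N+](=O)[O-])cc1` with 1600000 nM sits within the scatter of it, while compound 1 `CCCCCCCC(=O)OCCc1c(-c2ccccc2Cl)c2cc(Cl)ccc2[nH]c1=O` with 78000 nM lies far lower. Compound 4 `O=C(/C=C/c1ccc(C(F)(F)F)cc1)OCCc1c(-c2ccccc2Cl)c2cc(Cl)ccc2[nH]c1=O` differs from compound 3 at the ester carbonyl: a group of 12 heavy atoms (9 carbon, 3 fluorine; one six-membered aromatic ring of carbon only) in place of a group of 12 heavy atoms (9 carbon, 1 nitrogen, 2 oxygen; one five-membered non-aromatic ring with 1 hetero atom, one six-membered aromatic ring of carbon only), on a carbonyl carbon. Within the data shown here, the steps that bear on this are a 21-fold higher number from compound 1 to compound 2 (1.31 log units; beyond the scatter) and a 12-fold higher number from compound 1 to compound 3 (1.09 log units; beyond the scatter), both exchanging the heptyl chain for an aryl-containing group, and a 1.7-fold lower number from compound 2 to compound 3 (0.22 log units; within the scatter), where two aryl-containing esters do not separate. Compound 4 keeps an aryl-containing ester, so in this assay no step beyond the scatter is expected: a 1.4-fold lower number from compound 3 to compound 4 (0.14 log units; within the scatter). Compound 4 is accordingly estimated at 700000 nM, with a range from 200000 nM to 2000000 nM.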

Compound 4, half-maximal cytotoxic concentration: > 1400000 nM
Compound 4: a limit, no number; the forecaster's own chance of this, stated with the estimate: 15%; at least 2.0-fold (0.30 log units) between middle value and limit.
By their numbers in this assay, from the lowest: compound 1; then compounds 3 and 2 (each within the scatter of the next).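

In this assay compound 4 gives > 1400000 nM, which is a limit and not a number. Replacing the heptyl chain with 2-(4-(trifluoromethyl)phenyl)ethenyl gives an at least 17-fold higher number from compound 1 to compound 4 (1.25 log units; beyond the scatter), so a third aryl-containing ester stands clear of the heptyl ester, and none of the compounds shown goes against this. Exchanging the group on this carbonyl carbon gives an at least 1.4-fold higher number from compound 3 to compound 4 (0.16 log units; that floor lies within the scatter), so an aryl-containing group without nitrogen or oxygen does not separate from the earlier one.

The step from compound 2 to compound 4 cannot be read. On these data alone, whether a shorter alkyl chain or an amine on the ester keeps the low number of the heptyl ester remains open.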